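The source may report more compounds than this note shows. Statements on the series, on what has been measured and on what is new or still open speak of the compounds shown alone.

Working notes on the series.

The shared core is carried by compound 1 `Cc1ccc(NS(=O)(=O)c2ccc(N3CCNC3=O)cc2)cc1`, compound 2 `Cc1cc(C)cc(NS(=O)(=O)c2ccc(N3CCNC3=O)cc2)c1` and compound 3 `Cc1ccc(NS(=O)(=O)c2ccc(N3CCNC3=O)cc2)c(C)c1`, which differ only in the methyl substitution of the aryl group on the sulfonamide nitrogen. In a functional assay on HT-29 cells (Homo sapiens) for antiproliferative activity, read by sulforhodamine B assay, with a stated time of 48 h (a higher number here means a weaker inhibitor, a lower number a stronger inhibitor), compound 1 gives 480 nM, the highest number of the three. Compound 2 gives 82 nM and compound 3 gives 180 nM. The two measured steps away from compound 1 are a 5.9-fold lower number from compound 1 to compound 2 (0.77 log units; beyond the scatter) and a 2.7-fold lower number from compound 1 to compound 3 (0.43 log units; beyond the scatter); between the dimethyl isomers there is a 2.2-fold higher number from compound 2 to compound 3 (0.34 log units; beyond the scatter).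

Compound 4 `CC(C)Cc1ccc(NS(=O)(=O)c2ccc(N3CCNC3=O)cc2)cc1` differs from compound 1 in that (isopropyl in place of hydrogen on a saturated chain carbon bound to an aromatic carbon). Going by the values given here, none of the measured steps changes a group at this place: both steps from compound 1 add methyl on an aromatic carbon, not on the saturated chain carbon. They show only that modest enlargement of this aryl group has so far lowered the number, never raised it beyond the scatter. A modest step is therefore expected, more likely downward, as a 1.6-fold lower number from compound 1 to compound 4 (0.20 log units; within the scatter). Compound 4 is estimated at 300 nM, with a range from 100 nM to 1000 nM.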

Compound 4, half-maximal inhibitory concentration: > 1000 nM
Compound 4 was reported as a limit; the forecaster's own chance of this, stated with the estimate: 3%; middle value at least 3.3-fold (0.52 log units) from the limit.
By their numbers in this assay, from the lowest: compound 2; then compound 3; then compound 1. At a limit, above all of these: compound 4.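

In this assay compound 4 is reported only as a limit, > 1000 nM, not as a number. Isobutyl in place of methyl, on the aromatic carbon that carries the methyl of compound 1, gives an at least 2.0-fold higher number from compound 1 to compound 4 (0.31 log units; beyond the scatter), so added carbon on this aryl group does not lower the number in general: compound 2 and compound 3 follow that trend, and compound 4 goes against it. Going by these compounds, the true size of this step stays unknown, and only its lower bound is fixed by the limit of the reading: the limit of > 1000 nM in this assay, at which 1 of the 4 values shown sits.

The compounds shown leave open whether the rise follows from the branching of the isobutyl group or from the length of the chain. An ethyl group, a straight butyl chain or an aminomethyl group in place of the methyl would separate these readings.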